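The source may report more compounds than this note shows. Statements on the series, on what has been measured and on what is new or still open speak of the compounds shown alone.

In a physicochemical assay for solubility, in phosphate buffer, with a stated time of 18 h, at pH 7 (a lower number here means a less soluble compound, a higher number a more soluble compound), compound 1 `CC(=O)N1CCCC([C@@H]2[C@@H](C(=O)Nc3ccc(F)c(C#N)c3)c3ccccc3C(=O)N2CC(C)C)C1` gives 69000 nM. Compound 2 `CC(C)CN1C(=O)c2ccccc2[C@H](C(=O)Nc2ccc(F)c(C#N)c2)[C@H]1c1ccsc1` gives < 1000 nM, which is a limit of the assay. Compound 3 `CC(C)CN1C(=O)c2ccccc2[C@H](C(=O)Nc2ccc(F)c(C#N)c2)[C@H]1c1ccco1` gives 13000 nM.

Compound 1 holds the highest of the two numbers, and the nearest is compound 3, with a 5.3-fold lower number from compound 1 to compound 3 (0.72 log units; beyond the scatter). Compound 4 `CC(C)CN1C(=O)c2ccccc2[C@H](C(=O)Nc2ccc(F)c(C#N)c2)[C@H]1c1ccc(C(N)=O)s1` differs from compound 1 in one place: 5-carbamoylthiophen-2-yl in place of 1-acetylpiperidin-3-yl on a saturated ring carbon. Among the compounds with values here, two measured steps bear on this, each replacing the same group with a five-membered aromatic ring: an at least 69-fold lower number from compound 1 to compound 2 (1.83 log units; beyond the scatter) and a 5.3-fold lower number from compound 1 to compound 3 (0.72 log units; beyond the scatter). Both point downward, the thiophene step more steeply. The entering group is again a thiophene, but with a carbamoyl group that brings a hydrogen-bond donor, so a smaller fall is expected: a 6.9-fold lower number from compound 1 to compound 4 (0.84 log units; beyond the scatter). Compound 4 is estimated at 10000 nM, most likely between 1000 nM and 60000 nM.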

Compound 4, solubility: 19000 nM
Estimate against measurement, compound 4: 1.9-fold (0.28 log units) below, within the range that was stated.
By their numbers in this assay, from the lowest: compounds 3 and 4 (each within the scatter of the next); then compound 1. At a limit, below all of these: compound 2.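

In this assay, a thiophene on this saturated ring carbon need not sit at the bottom: with 5-carbamoylthiophen-2-yl in place of thiophen-3-yl there is an at least 19-fold higher number from compound 2 to compound 4 (1.27 log units; beyond the scatter). Compound 2 gives a limit, not a number: the limit of < 1000 nM in this assay, at which 1 of the 4 values shown sits. Replacing 1-acetylpiperidin-3-yl with 5-carbamoylthiophen-2-yl still gives a 3.6-fold lower number from compound 1 to compound 4 (0.56 log units; beyond the scatter), while the furan-2-yl and 5-carbamoylthiophen-2-yl groups cannot be told apart, with a 1.5-fold higher number from compound 3 to compound 4 (0.16 log units; within the scatter).

Compound 2 and compound 4 differ both in the carbamoyl group and in how the thiophene is attached, and the compounds shown do not separate the two. Also open, going by these compounds, is what an amine or a carboxylic acid in place of the carbamoyl group would give.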